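Replacing phenyl on the sulfonyl sulfur of compound 3

The source may hold more compounds than are shown below. What is called first, only, known or untested is meant among the compounds shown, and "the series" means these compounds.

Measured compounds, with values in a physicochemical assay for lipophilicity, measured as octanol-water partition, at pH 7.4; a lower number here means a more polar compound, a higher number a more lipophilic compound:
- compound 1 `Cc1ccc2[nH]c(C(=O)N[C@H]3CN(S(=O)(=O)c4cccnc4)C[C@@H]3C(=O)NCCN(C)C)cc2c1` gives 1.4
- compound 2 `Cc1ccc2[nH]c(C(=O)N[C@H]3CN(S(=O)(=O)c4cnccn4)C[C@@H]3C(=O)NCCN(C)C)cc2c1` gives 1
- compound 3 `Cc1ccc2[nH]c(C(=O)N[C@H]3CCN(S(=O)(=O)c4ccccc4)C[C@@H]3C(=O)NCCN(C)C)cc2c1` gives 2.2

Compound 3 at 2.2 holds the highest of the three numbers, and compound 1 and compound 2 both lie lower by more than the scatter. Compound 3 differs from each of them in more than the sulfonyl group, so these gaps do not isolate a single change.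

Compound 4 `Cc1ccc2[nH]c(C(=O)N[C@H]3CCN(S(=O)(=O)N(C)C)C[C@@H]3C(=O)NCCN(C)C)cc2c1` has not yet been measured. Its difference from compound 3 is dimethylamino in place of phenyl on a sulfonyl sulfur, which turns phenylsulfonyl into dimethylsulfamoyl.

Within the data shown here, only one measured step falls at this place, a number 0.40 log units lower from compound 1 to compound 2 (beyond the scatter), and it exchanges one aromatic group for another. Among the measured compounds shown here, no measured step removes the aromatic ring from the sulfonyl sulfur, so this step is a loose guide to size only. With that step from compound 1 as the sole reference, a fall in this assay somewhat larger than it is expected, with wide uncertainty. The expected change is a number 0.60 log units lower from compound 3 to compound 4 (beyond the scatter) as an estimate. For compound 4 the estimated value is 1.6, with an expected range of 1.1 to 2 for the measurement.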

Compound 4, distribution coefficient: 1.2
Compound 4: the middle estimate sits 0.40 log units above what was measured; measured number inside the range.
By their numbers in this assay, from the lowest: compounds 2, 4 and 1 (each within the scatter of the next, the first and the last beyond it); then compound 3.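

In this assay, dimethylamino in place of phenyl on the sulfonyl sulfur gives a number 1.00 log units lower from compound 3 to compound 4 (beyond the scatter), so this place responds clearly to a change that removes the aromatic ring and not only to an exchange of one aromatic group for another. The earlier step at this place, a number 0.40 log units lower from compound 1 to compound 2 (beyond the scatter), is the smaller of the two printed steps, but it sits on a core that differs from that of compound 3, so the two sizes are not a like-for-like comparison. Nothing at hand shows which part of the change accounts for the fall, whether the loss of the ring, the smaller group or the entering nitrogen.

The compounds shown leave open whether a simple methyl group on the sulfonyl sulfur, or a cyclic amine such as morpholine, would follow the step to compound 4, which would help separate the loss of the ring from the presence of the amine. Also open, on these data alone, is whether the exchange of pyridin-3-yl for pyrazin-2-yl carries over to the core of compound 3.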